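From Cyano to Carbamoyl on a Potent Compound

This account rests on a few compounds, and the source may have more. Where it says the series, first, only, none or still open, it means among the compounds named here.

Within the data shown here, only two compounds have numbers so far. In a functional assay on HT-29 cells (Homo sapiens) for inhibition, read by MTT assay (on this read-out higher numbers stand for weaker inhibition and lower numbers for stronger inhibition), compound 2 (`COc1ccc(/C=C2\c3cc(OC)c(OC)c(OC)c3CC[C@@H]2O)cc1C#N`) gives 5 nM as the lower of the two numbers. Compound 1 (`COc1ccc2c(c1)CC[C@@H](O)/C2=C/c1cc(OC)c(OC)c(OC)c1`) gives 900 nM in this assay and that gap lies beyond the usual scatter of repeated measurements. These two compounds differ in more than one place, and their gap cannot be pinned on any single group.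

The next compound, compound 3 (`COc1ccc(/C=C2\c3cc(OC)c(OC)c(OC)c3CC[C@@H]2O)cc1C(N)=O`), alters compound 2 in one place: carbamoyl in place of cyano on an aromatic carbon. That carbon is ortho to a methoxy group. Among the measured compounds shown here, no measured pair here shows this swap, and the expectation is a judgement rather than a trend. Compound 2 already stands at 5 nM and a single change from so low a number seems more likely to raise it than to lower it. In this assay the expected step is a 10-fold higher number from compound 2 to compound 3 (1.00 log units; beyond the scatter) toward weaker inhibition and beyond the scatter. Compound 3 is estimated at 50 nM with 8 nM to 400 nM as the expected range.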

Compound 3, half-maximal inhibitory concentration: 550 nM
Compound 3: middle estimate off by 11-fold (1.04 log units), on the low side; the measured number lies above the stated range.
By their numbers in this assay, from the lowest: compound 2; then compounds 3 and 1 (each within the scatter of the next).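

In this assay the swap of cyano for carbamoyl on this aromatic carbon, ortho to a methoxy group, brings a 110-fold higher number from compound 2 to compound 3 (2.04 log units; beyond the scatter) and shows that this one position is far from indifferent to what sits on it. Compound 1 and compound 2 differ in more than one place, so their gap could not reveal this, whereas here the rest of the structure stays the same and the whole step belongs to one change. The entering carbamoyl has 3 heavy atoms and 1 hydrogen-bond donor against 2 heavy atoms and 0 hydrogen-bond donors for the leaving cyano, but no measurement here ties the step to either difference or to anything else.

The compounds shown leave open how other groups on this same carbon would read, such as a carboxylic acid, an aminomethyl group or a plain methyl group. Among these compounds, with only two groups compared at this carbon, it also remains open whether cyano is unusually favourable here or carbamoyl is unusually unfavourable.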